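Swapping Hydroxy for Chloro on the Ketone-Bearing Ring

The source may report more compounds than this note shows. Statements on the series, on what has been measured and on what is new or still open speak of the compounds shown alone.

Compound 1, `COc1ccc(C(=O)/C=C/c2cc3ccccc3[nH]c2=O)cc1`, gives 21100 nM in a functional assay on HCT-15 cells (Homo sapiens) for cytotoxicity, read by sulforhodamine B assay, with a stated time of 24 h; on this read-out higher numbers stand for weaker inhibition of growth and lower numbers for stronger inhibition of growth.
Compound 2, `O=C(/C=C/c1cc2ccccc2[nH]c1=O)c1ccc(O)cc1`, gives 12800 nM in this assay.

Among the compounds with values here, only two compounds have numbers so far, and compound 2 holds the lower of them; its nearest neighbour is compound 1, and the step of a 1.6-fold lower number from compound 1 to compound 2 (0.22 log units; within the scatter) falls within the scatter, so the two cannot be told apart with confidence.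

Compound 3, `O=C(/C=C/c1cc2ccccc2[nH]c1=O)c1ccc(Cl)cc1`, is the next member. Its difference from compound 2 is chloro in place of hydroxy on an aromatic carbon, the hydroxy sitting on the six-membered aromatic ring of carbon only, para to a large group; seen one bond further out, a 4-hydroxyphenyl becomes a 4-chlorophenyl.

Within the data shown here, no measured step bears directly on this exchange. Among the measured compounds shown here, the one step available, a 1.6-fold lower number from compound 1 to compound 2 (0.22 log units; within the scatter), changes what sits on the same oxygen but keeps the oxygen in place, and it stayed within the scatter. Nothing here points to a move beyond the scatter in this assay for compound 3 in either direction.

Compound 3 is therefore estimated at 15000 nM, with a range from 5000 nM to 45000 nM, and the expected step is a 1.2-fold higher number from compound 2 to compound 3 (0.07 log units; within the scatter).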

Compound 3, concentration for total growth inhibition: 20200 nM
Compound 3: the middle estimate sits 1.3-fold (0.13 log units) below what was measured; low and high end bracket the measured number.
By their numbers in this assay, from the lowest: compounds 2, 3 and 1 (each within the scatter of the next).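

In this assay the step of a 1.6-fold higher number from compound 2 to compound 3 (0.20 log units; within the scatter) and the step of a 1.0-fold lower number from compound 1 to compound 3 (0.02 log units; within the scatter) both fall within the scatter, so hydroxy, methoxy and chloro on this aromatic carbon give numbers that cannot be told apart. The earlier pair changed only what sits on the oxygen, whereas compound 3 has no oxygen at this place and loses the hydrogen-bond donor and acceptor counted for hydroxy, and even this larger exchange produces no difference that can be read in these three compounds. No measurement shown here explains why the three read alike.

Whether an amine, a carboxylic acid or a longer chain on the oxygen would also fall within the scatter of these compounds remains open. All three compounds carry their group at the same place on the ring, so they also leave open what chloro or hydroxy would do elsewhere on that ring or on the rest of the shared core.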